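A few compounds are considered here, and "the series" means these few. Any claim that something is new, unique, unknown or untested is made for them only; others in the source may bear on it.

Going by the values given here, compound 2 `Cc1ccc(S(=O)(=O)c2cnc3ccc(Cl)cc3c2N2CCC(C)CC2)cc1` gives 95% in an assay on isolated protein for displacement of a labelled ligand from metabotropic glutamate receptor 5 (Homo sapiens), with a stated time of 60 min, tested at 1 uM (a higher number here means more inhibition at the concentration tested (going by the name of the read-out), a lower number less inhibition), the higher of the two numbers measured so far; compound 1 `Cc1ccc(S(=O)(=O)c2cnc3ccc(Cl)cc3c2N2CCC(C)CC2)cc1F` gives 68%, and the step of a number 27 percentage points higher from compound 1 to compound 2 (beyond the scatter) followed hydrogen in place of fluoro on an aromatic carbon. Compound 3 `Cc1cc(C)cc(S(=O)(=O)c2cnc3ccc(Cl)cc3c2N2CCC(C)CC2)c1` has not yet been measured. It differs from compound 2 by 3,5-dimethylphenyl in place of 4-methylphenyl on a sulfonyl sulfur. Among the compounds with values here, the one measured step sits on the same sulfonyl-bound aryl ring but concerns a different substituent change, so it bears on the new step only loosely, showing that a single substituent change on this ring moved the read-out by a modest amount. Compound 2 already stands at a high number in this assay, leaving little room upward, so a modest downward step is expected, a number 15 percentage points lower from compound 2 to compound 3 (beyond the scatter), though a result within the scatter would not surprise. Compound 3 is therefore estimated at 80%, with a range from 55% to 98%.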

Compound 3, a percentage reported as inhibition, at one concentration (the size of the read-out at that concentration, not a potency): 49%
For compound 3 the middle estimate is 31 percentage points above the measured one; measured number outside the range, below it.
By their numbers in this assay, from the lowest: compound 3; then compound 1; then compound 2.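

In this assay, 3,5-dimethylphenyl in place of 4-methylphenyl on the sulfonyl sulfur gives a number 46 percentage points lower from compound 2 to compound 3 (beyond the scatter) and is a large step, so this position responds strongly to more than the fluoro change seen earlier. The comparison with the fluorinated analogue gives a number 19 percentage points lower from compound 1 to compound 3 (beyond the scatter) and is a modest step, which places 3,5-dimethylphenyl below both 4-methylphenyl and 3-fluoro-4-methylphenyl among these three compounds. No measurement shown accounts for these differences.

The compounds shown leave open whether the drop follows the loss of the 4-methyl group, the arrival of two methyl groups elsewhere on the ring, or both. A plain phenyl or a 3-methylphenyl group on the sulfonyl sulfur would help separate these readings.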